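The source may hold more compounds than are shown below. What is called first, only, known or untested is meant among the compounds shown, and "the series" means these compounds.

Measured so far in a functional assay on PC-3 cells (Homo sapiens) for antiproliferative activity, read by MTT assay, with a stated time of 24 h; on this read-out higher numbers stand for weaker inhibition and lower numbers for stronger inhibition:
compound 1 `CCn1c(C(=O)N[C@H](C)C(=O)OC)ccc1C(CC)(CC)c1ccc(OCS(=O)(=O)c2ccccc2)c(C)c1`: > 50000 nM
compound 2 `CCn1c(C(=O)N[C@H](CO)CCO)ccc1C(CC)(CC)c1ccc(OCS(=O)(=O)c2ccccc2)c(C)c1`: 12100 nM

Compound 1 sits at a limit of this assay, (the limit of > 50000 nM in this assay, at which 1 of the 2 values shown sits), so it gives no number of its own. Compound 3 `CCn1c(C(=O)N[C@@H](CO)CCO)ccc1C(CC)(CC)c1ccc(OCS(=O)(=O)c2ccccc2)c(C)c1` differs from compound 1 by 3-hydroxy-1-(hydroxymethyl)propyl in place of 1-(methoxycarbonyl)ethyl on an amide-type nitrogen. Going by the values given here, the same change in words, made in compound 2, gave an at least 4.1-fold lower number from compound 1 to compound 2 (0.61 log units; beyond the scatter), the only measured step that bears on it. Compound 3 is therefore expected to show a step of an at least 3.3-fold lower number from compound 1 to compound 3 (0.52 log units; beyond the scatter) in this assay. On that basis compound 3 is estimated at 15000 nM, within 5000 nM to 45000 nM.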

Compound 3, half-maximal inhibitory concentration: 14100 nM
Compound 3: the middle estimate sits 1.1-fold (0.03 log units) above what was measured; the measured number falls inside the stated range.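

In this assay, the 3-hydroxy-1-(hydroxymethyl)propyl group also gives a lower number in its other drawn configuration, with an at least 3.5-fold lower number from compound 1 to compound 3 (0.54 log units; beyond the scatter). The two configurations are not separated here, with a 1.2-fold higher number from compound 2 to compound 3 (0.07 log units; within the scatter), so this stereocentre shows no effect in this assay, the cleanest reading the pair allows: the fact that compounds 2 and 3 differ only in the configuration as drawn Compound 1, at > 50000 nM, is a limit and not a number: the limit of > 50000 nM in this assay, at which 1 of the 3 values shown sits.

Going by these compounds, it remains open whether the hydroxyl groups or the loss of the methoxycarbonyl accounts for the lower numbers. On these data alone, it is also open how an amine or a carboxylic acid on this chain would compare.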